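Benzyl groups on the aromatic nitrogen of compound 2

The compounds below may be only part of what the source reports. "The series", "measured", "known", "first", "only" and "open" are said of these compounds alone.

Compound 2 `N#C/C(=C\c1c[nH]c2ccccc12)C(=O)c1c[nH]c2ccccc12` bears a hydrogen on the aromatic nitrogen. In a functional assay on MIA PaCa-2 cells (Homo sapiens) for cytotoxicity, read by WST assay, with a stated time of 24 h (a higher number here means a weaker inhibitor, a lower number a stronger inhibitor), compound 2 gives 17900 nM. Of the two numbers measured this is the larger, yet the gap to compound 3 `COc1ccc2c(C(=O)/C(C#N)=C/c3c[nH]c4ccccc34)c[nH]c2c1`, which in this assay gives 13500 nM, is a 1.3-fold lower number from compound 2 to compound 3 (0.12 log units; within the scatter) and stays within the scatter. Compound 1 `N#C/C(=C\c1cn(Cc2ccc(Cl)cc2)c2ccccc12)C(=O)c1c[nH]c2ccccc12` does not reach a number in this assay but sits at the limit (the limit of > 50000 nM in this assay, at which 1 of the 3 values shown sits), recorded as > 50000 nM. The step of an at least 2.7-fold lower number from compound 1 to compound 2 (0.44 log units; beyond the scatter) accompanies hydrogen in place of 4-chlorobenzyl on an aromatic nitrogen.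

Compound 4 `COc1ccc(Cn2cc(/C=C(\C#N)C(=O)c3c[nH]c4ccccc34)c3ccccc32)cc1` differs from compound 2 by 4-methoxybenzyl in place of hydrogen on an aromatic nitrogen. Within the data shown here, the one measured step that bears on this change is an at least 2.7-fold lower number from compound 1 to compound 2 (0.44 log units; beyond the scatter); read in the opposite direction, it points to a higher number beyond the scatter, with the possibility that only a limit is returned. Compound 4 is therefore expected to give about 60000 nM in this assay, between 25000 nM and 150000 nM. The expected step is a 3.4-fold higher number from compound 2 to compound 4 (0.53 log units; beyond the scatter).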

Compound 4, half-maximal inhibitory concentration: > 50000 nM
Compound 4: only a limit was reported; the forecaster's own chance of this, stated with the estimate: 60%; the middle value is on the limit's open side.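

On the aromatic nitrogen, a second benzyl group now gives the same outcome as the first: in this assay the step is an at least 2.7-fold higher number from compound 2 to compound 4 (0.44 log units; beyond the scatter), so the loss is not confined to 4-chlorobenzyl and holds for 4-methoxybenzyl as well. The change of methoxy for chloro on the benzyl group cannot be read, since compound 1 and compound 4 are both reported only as limits, not as numbers. The two benzyl compounds therefore share one ceiling: the limit of > 50000 nM in this assay, at which 2 of the 4 values shown sit.

Any difference between compound 1 and compound 4 lies beyond that limit, so the two substituents on the benzyl group stay unranked. Also open, from the compounds shown here alone, is how compound 2 would respond to a methyl group or to a longer chain ending in an amine on the same nitrogen.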